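The source may hold more compounds than are shown below. What is called first, only, known or untested is meant among the compounds shown, and "the series" means these compounds.

Working notes on an ADME assay on microsomes from liver (Homo sapiens) for metabolic stability (a higher number here means faster removal of the compound, a lower number slower removal), across this series. Compound 1 (`CCCC(Oc1ccc(-n2cc(OC)cn2)cc1)c1ccc(C(=O)NCCC(=O)O)cc1`) reads < 8 mL/min/kg and this value is a limit. Among the measured compounds shown here, compound 3 (`O=C(O)CCNC(=O)c1ccc(C(Oc2ccc(-n3cc(C(F)(F)F)cn3)cc2)C2CCC2)cc1`) gives 26 mL/min/kg and sits within the scatter of compound 2 (`CCCC(Oc1ccc(-n2cc3ccccc3n2)cc1)c1ccc(C(=O)NCCC(=O)O)cc1`), which gives 44 mL/min/kg as the only other number so far. For the measured compounds named here, the one measured step, an at least 5.5-fold higher number from compound 1 to compound 2 (0.74 log units; beyond the scatter), comes with 2H-indazol-2-yl in place of 4-methoxy-1H-pyrazol-1-yl on an aromatic carbon. Compound 4 (`O=C(O)CCNC(=O)c1ccc(C(Oc2ccc(-n3cc(C(F)(F)F)cn3)cc2)C2CCCC2)cc1`) carries cyclopentyl in place of cyclobutyl on a saturated chain carbon bound to an aromatic carbon and an oxygen on an aromatic ring. The measured step lies elsewhere in the structure and gives no size for this change. No step beyond the scatter is therefore expected in this assay here. The expectation starts from compound 3 at 26 mL/min/kg as measured. The estimated change is a 1.2-fold higher number from compound 3 to compound 4 (0.06 log units; within the scatter) and stays within the scatter. For compound 4 the estimate is 30 mL/min/kg with an expected range of 14 mL/min/kg to 60 mL/min/kg for now.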

Compound 4, clearance: 22 mL/min/kg
Beside the measured number, compound 4's estimate is 1.4-fold (0.13 log units) above it, and the stated range covers the measured number.
By their numbers in this assay, from the lowest: compounds 4, 3 and 2 (each within the scatter of the next). At a limit, below all of these: compound 1.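

In this assay, among the compounds shown here, the step of a 1.2-fold lower number from compound 3 to compound 4 (0.07 log units; within the scatter) gives the only size so far for a change on the saturated chain carbon bound to an aromatic carbon and an oxygen on an aromatic ring; the one earlier step lay elsewhere in the structure. It lies within the scatter, so cyclopentyl and cyclobutyl at this place cannot be told apart in this read-out, and the place accepts the five-membered ring as well as the four-membered one with no step beyond the scatter. Nothing in the data shown bears on why these two rings read alike.

Open, as far as these compounds go, is whether a larger ring such as cyclohexyl, or a hydroxyl or an amine on the cyclopentyl ring, would give a step beyond the scatter at this place. Also open, from the compounds shown here alone, is how an open chain at this carbon compares with these rings when the rest of the structure is that of compound 3.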